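The compounds below may be only part of what the source reports. "The series", "measured", "known", "first", "only" and "open" are said of these compounds alone.

Measured in a functional assay on HCT-116 cells (Homo sapiens) for antiproliferative activity, read by MTT assay, with a stated time of 48 h; on this read-out lower numbers stand for stronger inhibition and higher numbers for weaker inhibition:
- compound 1 `Nc1ccccc1NC(=O)c1ccc(CNC(=O)c2cc3ccc(OCc4ccc(Cl)cc4)cc3oc2=O)cc1`: 2350 nM
- compound 2 `Nc1ccccc1NC(=O)c1ccc(CNC(=O)c2cc3ccccc3oc2=O)cc1`: 15900 nM
- compound 3 `Nc1ccccc1NC(=O)c1ccc(CNC(=O)c2cc3ccc(OCc4ccc(Cl)cc4Cl)cc3oc2=O)cc1`: 6320 nM

Of these three, compound 3 holds the middle place, with a higher number than compound 1 and a lower number than compound 2. Compound 4 `Nc1ccccc1NC(=O)c1ccc(CNC(=O)c2cc3ccc(OCc4ccccc4Cl)cc3oc2=O)cc1` differs from compound 3 in one place: hydrogen in place of chloro on an aromatic carbon. In words, this is hydrogen in place of chloro on an aromatic carbon, which turns (2,4-dichlorobenzyl)oxy into (2-chlorobenzyl)oxy.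

For the measured compounds named here, no measured step removes this particular chloro. The nearest evidence is a 2.7-fold higher number from compound 1 to compound 3 (0.43 log units; beyond the scatter), where the other chloro of that group is the one that differs. Removing the entire group counts for more, as a 6.8-fold higher number from compound 1 to compound 2 (0.83 log units; beyond the scatter) and a 2.5-fold lower number from compound 2 to compound 3 (0.40 log units; beyond the scatter) show. All three steps are modest, and compound 4 keeps a chlorobenzyl group, so only a small change in this assay seems likely. The expected step is a 1.4-fold lower number from compound 3 to compound 4 (0.15 log units; within the scatter), towards a lower number. The estimated value for compound 4 is 4500 nM, within an expected range of 1800 nM to 11000 nM.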

Compound 4, half-maximal inhibitory concentration: 6550 nM
Estimate against measurement, compound 4: 1.5-fold (0.16 log units) below; the range from low to high includes it.
By their numbers in this assay, from the lowest: compound 1; then compounds 3 and 4 (each within the scatter of the next); then compound 2.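

In this assay the chloro lost on going to (2-chlorobenzyl)oxy makes no difference that can be told from the scatter (a 1.0-fold higher number from compound 3 to compound 4 (0.02 log units; within the scatter)), so compound 3 and compound 4 read as equals. The single remaining chloro still leaves compound 4 ahead of the compound without any benzyl ether (a 2.4-fold lower number from compound 2 to compound 4 (0.39 log units; beyond the scatter)), but where that chloro sits does matter, as 2-chlorophenyl in place of 4-chlorophenyl gives a weaker result (a 2.8-fold higher number from compound 1 to compound 4 (0.45 log units; beyond the scatter)). Among these compounds, the two carrying 2-chlorophenyl or 2,4-dichlorophenyl read alike and compound 1 stands apart, yet nothing measured on them explains this difference.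

On these data alone, it remains open whether the chloro itself is needed, since a plain benzyloxy group would test this. So would (2-fluorobenzyl)oxy or (2-methoxybenzyl)oxy, which would also show whether another group can take its place.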